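The source may report more compounds than this note shows. Statements on the series, on what has been measured and on what is new or still open speak of the compounds shown alone.

Measured compounds:
compound 1 `O=C(c1cccc(Cl)c1)N1CCC(NS(=O)(=O)c2cc(S(=O)(=O)c3ccccc3)ccc2C(F)(F)F)CC1` — 870 nM
compound 2 `O=C(O)c1cccc(S(=O)(=O)N2CCC(NS(=O)(=O)c3cc(S(=O)(=O)c4ccccc4)ccc3C(F)(F)F)CC2)c1` — 190 nM
compound 3 `N#Cc1cccc(S(=O)(=O)N2CCC(NS(=O)(=O)c3cc(S(=O)(=O)c4ccccc4)ccc3C(F)(F)F)CC2)c1` — 170 nM

In an assay on U2OS cells for inhibition of secreted frizzled-related protein 1 (Homo sapiens), read by a luciferase reporter, with a stated time of 18 h (on this read-out higher numbers stand for an effect only at larger amounts of compound and lower numbers for an effect already at smaller amounts), compound 1 gives 870 nM and stands highest of the three numbers. The two measured steps both leave this compound and reach lower numbers: a 4.6-fold lower number from compound 1 to compound 2 (0.66 log units; beyond the scatter) and a 5.1-fold lower number from compound 1 to compound 3 (0.71 log units; beyond the scatter), each changing the group on the amine nitrogen in the ring from a carbonyl-linked aryl to a sulfonyl-linked aryl carrying a polar substituent. Between compound 2 and compound 3 the step is a 1.1-fold lower number from compound 2 to compound 3 (0.05 log units; within the scatter).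

Compound 4 `CC(C)(C)OC(=O)N1CC[C@H](C(=O)N2CCC(NS(=O)(=O)c3cc(S(=O)(=O)c4ccccc4)ccc3C(F)(F)F)CC2)C1` keeps the carbonyl on that nitrogen and changes only what sits on the carbonyl carbon: 1-(tert-butoxycarbonyl)pyrrolidin-3-yl in place of 3-chlorophenyl on a carbonyl carbon. Within the data shown here, no measured step alters the carbonyl-attached group alone, so the steps to compound 2 and compound 3 bear on it only loosely, in showing that this position tolerates change and can move the number by a modest amount. Among the measured compounds shown here, with no direct precedent, a step in this assay near or somewhat weaker than the scatter is expected, a 1.4-fold higher number from compound 1 to compound 4 (0.14 log units; within the scatter), in an uncertain direction. The estimate for compound 4 is 1200 nM, with a range of 350 nM to 4000 nM.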

Compound 4, half-maximal effective concentration: 150 nM
For compound 4 the middle estimate is 8.0-fold (0.90 log units) above the measured one, and the stated range ends above it.
By their numbers in this assay, from the lowest: compounds 4, 3 and 2 (each within the scatter of the next); then compound 1.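

In this assay the carbonyl on the ring nitrogen stays and only the group on the carbonyl carbon changes, giving a 5.8-fold lower number from compound 1 to compound 4 (0.76 log units; beyond the scatter). Among these compounds, the earlier steps changed the link and the aryl group together, whereas this one shows that the group on the carbonyl carbon can move the number by itself, and that a sulfonyl link is not required for a value such as the one compound 4 gives, 150 nM, with a non-aromatic ring in place of the 3-chlorophenyl ring. Nothing at hand explains this step.

Still open, going by these compounds, is whether the step follows the pyrrolidine ring or the tert-butoxycarbonyl group, which a free pyrrolidine amine or an acetyl group on that nitrogen would separate. On these data alone, the opposite stereocentre at the pyrrolidin-3-yl carbon also remains open.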